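Swapping a Methyl for a Chlorine on the Anilino Arm

This account rests on a few compounds, and the source may have more. Where it says the series, first, only, none or still open, it means among the compounds named here.

compound 1 `COc1cc(/C=C/C(=O)c2sc(Nc3ccccc3C)nc2C)cc(OC)c1OC`: 10300 nM
compound 2 `COc1ccc(/C=C/C(=O)c2sc(Nc3ccc(Cl)c(Cl)c3)nc2C)cc1`: > 25000 nM
compound 3 `Cc1nc(Nc2ccccc2)sc1C(=O)/C=C/c1ccc(Cl)cc1`: > 25000 nM

In a functional assay on Bel-7402 cells (Homo sapiens) for cytotoxicity, read by MTT assay (a higher number here means a weaker inhibitor, a lower number a stronger inhibitor), compound 1 gives 10300 nM. Compound 2 reaches only a limit of this assay, > 25000 nM. Compound 3 likewise reaches only a limit, > 25000 nM. Within the data shown here, compound 1 therefore holds the only real number in this assay, the other two sitting at the limit of > 25000 nM in this assay, at which 2 of the 3 values shown sit. Compound 4 `COc1cc(/C=C/C(=O)c2sc(Nc3cccc(Cl)c3)nc2C)cc(OC)c1OC` differs from compound 1 by 3-chlorophenyl in place of 2-methylphenyl on a nitrogen on an aromatic ring. Among the measured compounds shown here, no pair of measured compounds isolates this change, so its size is unknown from the data. Compound 4 is expected to move by a 1.7-fold higher number from compound 1 to compound 4 (0.24 log units; within the scatter), toward weaker cytotoxicity, with a fair chance of ending at a limit. The estimate for compound 4 is 18000 nM, between 6000 nM and 50000 nM.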

Compound 4, half-maximal inhibitory concentration: 14000 nM
Compound 4: the middle estimate sits 1.3-fold (0.11 log units) above what was measured; the measured number falls inside the stated range.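

In this assay, this position now has its first readable step, a 1.4-fold higher number from compound 1 to compound 4 (0.13 log units; within the scatter). On this nitrogen, 2-methylphenyl and 3-chlorophenyl therefore cannot be told apart on the shared core of compound 1. Compound 4 also gives a real number, not a limit of the assay: the limit of > 25000 nM in this assay, at which 2 of the 4 values shown sit.

The names of the two groups differ in both the substituent and its number on the ring, and this single step cannot separate those two differences. On these data alone, what a phenyl ring carrying an amine or a carboxylic acid would give on this nitrogen stays open.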